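This account rests on a few compounds, and the source may have more. Where it says the series, first, only, none or still open, it means among the compounds named here.

Among the measured compounds shown here, in a functional assay (on this read-out lower numbers stand for stronger inhibition and higher numbers for weaker inhibition), compound 1 (`COc1ccc(-c2nn(-c3ccccc3)cc2/C=C2\SC(=O)N(Cc3ccccc3)C2=O)cc1`) gives 127 ug/mL, the higher of the two numbers so far. Compound 2 (`O=C(c1ccccc1)c1ccc(O)cc1Br`) gives 19.2 ug/mL, lower by more than the scatter. Compound 3 (`O=C1S/C(=C\c2cn(-c3ccccc3)nc2-c2ccc(O)cc2)C(=O)N1Cc1ccccc1`) differs from compound 1 by hydrogen in place of methyl on an oxygen on an aromatic ring, or methoxy to hydroxy. For the measured compounds named here, no measured step isolates this change. The only weak hint is that compound 2, otherwise a different structure, also has a hydroxy on an aromatic ring. The expected change is a 2.1-fold lower number from compound 1 to compound 3 (0.33 log units; beyond the scatter), a small shift toward stronger inhibition, close to the scatter. For compound 3 the estimated value is 60 ug/mL, with an expected range of 20 ug/mL to 170 ug/mL.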

Compound 3, half-maximal inhibitory concentration: 111 ug/mL
Compound 3: middle estimate off by 1.9-fold (0.27 log units), on the low side, and the stated range covers the measured number.
By their numbers in this assay, from the lowest: compound 2; then compounds 3 and 1 (each within the scatter of the next).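

In this assay, among the compounds shown here, methoxy to hydroxy on the aromatic ring reads as a 1.1-fold lower number from compound 1 to compound 3 (0.06 log units; within the scatter), the only direct reading of this change. At this position on the shared core, hydrogen in place of methyl does not move the read-out beyond the scatter, so the hydroxy brings no detectable gain in inhibition. No supporting measurement bears on this result.

Still open, on these data alone, is whether a different group at this position, such as an amine or a carboxylic acid, would shift the number. Also open, as far as these compounds go, is whether methoxy to hydroxy behaves the same way on another core.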